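A few compounds are considered here, and "the series" means these few. Any claim that something is new, unique, unknown or untested is made for them only; others in the source may bear on it.

Among the compounds with values here, compound 3 `CC(C)COC(=O)N1CCC(Oc2ncnc3c2CCN3c2ccc(S(C)(=O)=O)cc2F)CC1` gives 25.1 nM in a functional assay on CHO-K1 cells for agonist activity at Glucose-dependent insulinotropic receptor (Homo sapiens), read by a luciferase reporter, with a stated time of 5 h (a higher number here means that more compound is needed for the effect, a lower number that less compound is needed), the lowest of the three numbers so far. Compound 1 `CCCOC(=O)N1CCC(Oc2ncnc3c2CCN3c2ccc(S(C)(=O)=O)cc2F)CC1` gives 79.4 nM and compound 2 `CCCCOC(=O)N1CCC(Oc2ncnc3c2CCN3c2ccc(S(C)(=O)=O)cc2F)CC1` gives 50.1 nM. Compound 4 `CS(=O)(=O)c1ccc(N2CCc3c(OC4CCN(C(=O)OCCF)CC4)ncnc32)c(F)c1` differs from compound 3 by fluoromethyl in place of isopropyl on a saturated chain carbon bound to an oxygen next to a carbonyl group. The measured steps all follow growth of the same chain: a 1.6-fold lower number from compound 1 to compound 2 (0.20 log units; within the scatter), a 3.2-fold lower number from compound 1 to compound 3 (0.50 log units; beyond the scatter) and a 2.0-fold lower number from compound 2 to compound 3 (0.30 log units; within the scatter). Compound 4 moves the other way, towards a smaller group, so those steps point to a somewhat higher number, although none of them tests a fluorine and the direction is not secure. Compound 4 is therefore expected to give 63 nM (between 25 nM and 160 nM), which means an estimated step of a 2.5-fold higher number from compound 3 to compound 4 (0.40 log units; beyond the scatter) that may sit close to the edge of the scatter.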

Compound 4, half-maximal effective concentration: 501 nM
For compound 4 the middle estimate is 8.0-fold (0.90 log units) below the measured one; measured number outside the range, above it.
By their numbers in this assay, from the lowest: compounds 3, 2 and 1 (each within the scatter of the next, the first and the last beyond it); then compound 4.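

In this assay, this position tolerates the fluorinated chain far less than the earlier chain changes suggested, with a 20-fold higher number from compound 3 to compound 4 (1.30 log units; beyond the scatter). Within the data shown here, the unbranched chains show the same direction, with a 10-fold higher number from compound 2 to compound 4 (1.00 log units; beyond the scatter) and a 6.3-fold higher number from compound 1 to compound 4 (0.80 log units; beyond the scatter), the latter being fluoro in place of methyl, so a shorter carbon chain is not the only change that matters here. Nothing shown explains this rise. On these data alone, it remains open whether the rise follows from the fluorine itself or from the shorter carbon chain; an ethyl or 3-fluoropropyl chain at the same place would separate the two.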